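This account rests on a few compounds, and the source may have more. Where it says the series, first, only, none or still open, it means among the compounds named here.

Measured so far:
- compound 1 `c1ccc2c(c1)CN[C@@H](CN(CC1CCNCC1)[C@H]1CCCc3cccnc31)C2` gives 86%
- compound 2 `c1ccc2c(c1)CN[C@H](CN(CCCN1CCNCC1)[C@H]1CCCc3cccnc31)C2` gives 99%
- compound 3 `c1cnc(CN(CCCN2CCNCC2)[C@H]2CCCc3cccnc32)nc1` gives 100%

In an ADME assay on microsomes from liver (Homo sapiens) for metabolic stability, read by LC-MS, with a stated time of 10 min, tested at 0.5 uM (on this read-out lower numbers stand for a less stable compound and higher numbers for a more stable compound), compound 1 stands lowest of the three numbers, with compound 2 and compound 3 each beyond the scatter above it. Compound 4 `CN1CCN(CCCN(C[C@H]2Cc3ccccc3CN2)[C@H]2CCCc3cccnc32)CC1` differs from compound 1 by 2-(4-methylpiperazin-1-yl)ethyl in place of piperidin-4-yl on a saturated chain carbon bound to an amine nitrogen. Among the measured compounds shown here, the only computed step, a number 1 percentage points higher from compound 2 to compound 3 (within the scatter), lies within the scatter and falls at a different place on the molecule, so it gives no direct guide to this change. What the values of compound 2 and compound 3 show is that both measured compounds carrying a longer chain at this place read higher than compound 1. A moderate rise is therefore expected, a number 9 percentage points higher from compound 1 to compound 4 (within the scatter). Compound 4 is estimated at 95%, with a range from 82% to 100%.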

Compound 4, percent of the compound remaining: 72%
The estimate for compound 4 lay 23 percentage points above the measured number, and the stated range ends above it.
By their numbers in this assay, from the lowest: compound 4; then compound 1; then compounds 2 and 3 (each within the scatter of the next).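

In this assay, among the compounds shown here, the swap of piperidin-4-yl for 2-(4-methylpiperazin-1-yl)ethyl on a saturated chain carbon bound to an amine nitrogen gives a number 14 percentage points lower from compound 1 to compound 4 (beyond the scatter) and so provides the first step beyond the scatter at this place. This position therefore responds to the change, and the read-out moves towards a less stable compound. Nothing measured on hand explains this step.

Going by these compounds, it remains open which part of the entering group goes with the lower number. A morpholine ring on the same chain, or a shorter chain carrying the same 4-methylpiperazine, would help separate ring from chain length.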